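From compound 3 to compound 4: an ethoxy chain change

This account rests on a few compounds, and the source may have more. Where it says the series, first, only, none or still open, it means among the compounds named here.

Measured so far:
- compound 1 `C#Cc1cccc(Nc2ncnc3cc(OCCOCCn4ccnc4[N+](=O)[O-])c(OC)cc23)c1`: 6040 nM
- compound 2 `COc1cc2c(Nc3cccc(Br)c3)ncnc2cc1OCCCn1ccnc1[N+](=O)[O-]`: 2820 nM
- compound 3 `COc1cc2c(Nc3cccc(Br)c3)ncnc2cc1OCCCCn1ccnc1[N+](=O)[O-]`: 1430 nM

These values come from a functional assay on HT-29 cells (Homo sapiens) for inhibition, read by sulforhodamine B assay, with a stated time of 72 h; a lower number here means a stronger inhibitor, a higher number a weaker inhibitor. Compound 3 stands within the scatter of compound 2, and it gives a lower number than compound 1, a gap beyond the scatter.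

The next compound is compound 4 `COc1cc2c(Nc3cccc(Br)c3)ncnc2cc1OCCOCCn1ccnc1[N+](=O)[O-]`. It has 2-(2-nitro-1H-imidazol-1-yl)ethoxy in place of 2-(2-nitro-1H-imidazol-1-yl)ethyl on a saturated chain carbon, two bonds along the chain from an oxygen on an aromatic ring.

Going by the values given here, one measured step bears directly on this chain: a 2.0-fold lower number from compound 2 to compound 3 (0.29 log units; within the scatter). It stays within the scatter, so it gives no sign of a large response to chain changes. Compound 1, at 6040 nM, carries the same 2-(2-nitro-1H-imidazol-1-yl)ethoxy group but differs from compound 4 elsewhere, so it offers only a loose hint toward higher numbers in this assay.

No step beyond the scatter is therefore expected, and the estimated change is a 1.7-fold higher number from compound 3 to compound 4 (0.24 log units; within the scatter). For compound 4 the expected value is 2500 nM, with an estimated range from 1000 nM to 6000 nM.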

Compound 4, half-maximal inhibitory concentration: 3440 nM
For compound 4 the middle estimate is 1.4-fold (0.14 log units) below the measured one; the range from low to high includes it.
By their numbers in this assay, from the lowest: compounds 3, 2, 4 and 1 (each within the scatter of the next, the first and the last beyond it).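

In this assay, going by these compounds alone, 2-(2-nitro-1H-imidazol-1-yl)ethoxy in place of 2-(2-nitro-1H-imidazol-1-yl)ethyl gives a 2.4-fold higher number from compound 3 to compound 4 (0.38 log units; beyond the scatter), the first change on this chain to pass beyond the scatter, though only modestly. Set against (2-nitro-1H-imidazol-1-yl)methyl at the same place, the same group gives a 1.2-fold higher number from compound 2 to compound 4 (0.09 log units; within the scatter), while bromo in place of ethynyl on an aromatic carbon gives a 1.8-fold lower number from compound 1 to compound 4 (0.24 log units; within the scatter), so both of these steps stay within the scatter. Nothing in the data shown accounts for the step beyond the scatter.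

The compounds shown leave open how a longer chain, or an amine in place of the 2-nitro-1H-imidazol-1-yl group, would read in this assay. They also leave open how ethynyl in place of bromo would read on the chain of compound 3.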